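Methyl Replaces Trifluoromethyl: What Compound 3 Should Show

The source may hold more compounds than are shown below. What is called first, only, known or untested is meant among the compounds shown, and "the series" means these compounds.

Two compounds have been measured in a functional assay on HL-60 cells (Homo sapiens) for antiproliferative activity, with a stated time of 24 h; a higher number here means a weaker inhibitor, a lower number a stronger inhibitor:
Compound 1 `NC(=O)c1c(NC(=O)c2ccccc2Br)sc2c1CCN(C(=S)Nc1ccccc1Br)C2`: 17600 nM
Compound 2 `NC(=O)c1c(NC(=O)c2ccccc2Br)sc2c1CCN(C(=S)Nc1ccccc1C(F)(F)F)C2`: 27400 nM

Among the measured compounds shown here, compound 2 holds the higher of the two numbers, but the only measured step, a 1.6-fold higher number from compound 1 to compound 2 (0.19 log units; within the scatter), lies within the scatter, so the two are not distinguishable. Compound 3 `Cc1ccccc1NC(=S)N1CCc2c(sc(NC(=O)c3ccccc3Br)c2C(N)=O)C1` differs from compound 2 by methyl in place of trifluoromethyl on an aromatic carbon. For the measured compounds named here, the sole step bearing on this position is a 1.6-fold higher number from compound 1 to compound 2 (0.19 log units; within the scatter), within the scatter, so no change beyond the scatter is expected in this assay . Compound 3 is therefore estimated at 20000 nM, with a range of 7000 nM to 60000 nM. The implied step, a 1.4-fold lower number from compound 2 to compound 3 (0.14 log units; within the scatter), is expected to stay within the scatter.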

Compound 3, half-maximal inhibitory concentration: > 50000 nM
Compound 3: only a limit was reported; the forecaster's own chance of this, stated with the estimate: 10%; middle value at least 2.5-fold (0.39 log units) from the limit.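

The value of compound 3 in this assay is a limit and not a number: the limit of > 50000 nM in this assay, at which 1 of the 3 values shown sits. Methyl in place of bromo gives an at least 2.8-fold higher number from compound 1 to compound 3 (0.45 log units; beyond the scatter), the only step at this position that passes the scatter, so the group on this aromatic carbon can matter in this assay. Methyl in place of trifluoromethyl gives an at least 1.8-fold higher number from compound 2 to compound 3 (0.26 log units; that floor lies within the scatter), and that floor alone does not separate the two compounds.

From the compounds shown here alone, how far compound 3 lies past its limit stays open. Also open, going by these compounds, is how an amine, a hydroxyl or a carboxylic acid on this aromatic carbon would read in this assay.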